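Ethoxy to methoxy on the 1H-indol-5-yl compound

This account rests on a few compounds, and the source may have more. Where it says the series, first, only, none or still open, it means among the compounds named here.

Measured in a functional assay on HCT-116 cells (Homo sapiens) for antiproliferative activity, read by MTT assay, with a stated time of 48 h; on this read-out lower numbers stand for stronger inhibition and higher numbers for weaker inhibition:
- compound 1 `CCOc1cc(-c2ccc3cc[nH]c3c2)cn2c(-c3cc(OC)c(OC)c(OC)c3)nnc12`: 1340 nM
- compound 2 `CCOc1cc(-c2ccc3[nH]ccc3c2)cn2c(-c3cc(OC)c(OC)c(OC)c3)nnc12`: 374 nM

Of the two measured compounds, compound 2 has the lower number, at 374 nM. For the measured compounds named here, the only measured step is a 3.6-fold lower number from compound 1 to compound 2 (0.55 log units; beyond the scatter), which puts compound 2 clearly ahead of compound 1 at 1340 nM.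

Next in the series is compound 3 `COc1cc(-c2nnc3c(OC)cc(-c4ccc5[nH]ccc5c4)cn23)cc(OC)c1OC`, which keeps the 1H-indol-5-yl group of compound 2 and carries methoxy instead of ethoxy. The change is hydrogen in place of methyl on a saturated chain carbon bound to an oxygen on an aromatic ring.

Going by the values given here, no measured step touches this chain. The step from the 1H-indol-6-yl to the 1H-indol-5-yl group lies elsewhere on the molecule, so it gives only a rough sense of how far a single change can move this assay. The data give no direction for the new change, and no shift beyond the scatter is expected. The expected result is a 1.1-fold lower number from compound 2 to compound 3 (0.04 log units; within the scatter).

The estimate for compound 3 is 340 nM, with an expected range of 120 nM to 950 nM.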

Compound 3, half-maximal inhibitory concentration: 108 nM
Compound 3: middle estimate off by 3.1-fold (0.50 log units), on the high side, and the stated range ends above it.
By their numbers in this assay, from the lowest: compound 3; then compound 2; then compound 1.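

In this assay, the alkoxy chain proves to be a position that responds to a very small edit: with the 1H-indol-5-yl group held fixed, going from ethoxy to methoxy gives a 3.5-fold lower number from compound 2 to compound 3 (0.54 log units; beyond the scatter). Loss of a single methyl, one carbon and no hydrogen-bond donor or acceptor, therefore moves the read-out by about as much as the earlier change of indole attachment, a 3.6-fold lower number from compound 1 to compound 2 (0.55 log units; beyond the scatter), so both sites on the molecule bear on this read-out. No data shown account for the shift.

Going by these compounds, it remains open whether the read-out continues to follow chain length, as only ethoxy and methoxy appear here, and whether a hydroxyl, a propoxy chain or an aminoethoxy chain at the same place would extend, hold or reverse this step. It is also open whether the ethoxy-to-methoxy step carries over to the 1H-indol-6-yl series, since the two steps shown start from different compounds and say nothing about how the two changes combine.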